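The source may report more compounds than this note shows. Statements on the series, on what has been measured and on what is new or still open speak of the compounds shown alone.

Compound 1 `Cc1nnc(SCC(=O)c2ccccc2)n1N1C(=O)c2ccccc2C1=O` gives > 200000 nM in a functional assay on PC-3M cells (Homo sapiens) for cytotoxicity, read by MTT assay, with a stated time of 48 h (on this read-out lower numbers stand for stronger inhibition and higher numbers for weaker inhibition), which is a limit of the assay rather than a number. Compound 2 `C=CCSc1nnc(-c2cc(OC)c(OC)c(OC)c2)n1N1C(=O)c2ccccc2C1=O` gives > 200000 nM in this assay, again a limit. Compound 3 `COc1cc(-c2nnc(SC)n2N2C(=O)c3ccccc3C2=O)cc(OC)c1OC` gives > 200000 nM in this assay, also a limit.

Compound 3 thus stands at the limit of the assay, and every value shown sits there (the limit of > 200000 nM in this assay, at which 3 of the 3 values shown sit). For the measured compounds named here, the only one-place step between measured compounds, a step that the two limits leave unreadable from compound 2 to compound 3, cannot be read in size, since both of its ends are limits. Compound 4 `COc1cc(-c2nnc(SCC(=O)c3ccccc3)n2N2C(=O)c3ccccc3C2=O)cc(OC)c1OC` differs from compound 3 by benzoyl in place of hydrogen on a saturated chain carbon bound to a sulfur. Compound 1 carries the same (benzoylmethyl)sulfanyl group on a different core and likewise reaches only a limit. Going by the values given here, no measured step shows how this change moves the read-out, so there is no ground to expect a step beyond the scatter in this assay in either direction. The value of compound 4 is expected to be 300000 nM, with a range from 100000 nM to 1000000 nM, and most likely reported only as a limit. The expected step is accordingly a step that the limit leaves unreadable from compound 3 to compound 4.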

Compound 4, half-maximal inhibitory concentration: > 200000 nM
Compound 4 ended at the assay's limit; the forecaster's own chance of this, stated with the estimate: 85%; the middle value lies beyond the limit too.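

Compound 4 joins compound 1, compound 2 and compound 3 at a limit of the assay, so none of the steps to compound 4 can be read in size: the limit of > 200000 nM in this assay, at which 4 of the 4 values shown sit.

The compounds shown leave open whether any change to the group on the sulfur, or to the core, moves the read-out in this assay.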